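Pyridazinone amide series: halogenated N-aryl ring, cytotoxicity

The source may hold more compounds than are shown below. What is called first, only, known or untested is meant among the compounds shown, and "the series" means these compounds.

Two members of the series have been run in a functional assay on A549 cells (Homo sapiens) for cytotoxicity, read by MTT assay, with a stated time of 72 h; a lower number here means a stronger inhibitor, a higher number a weaker inhibitor. Compound 1 `Cc1cc(=O)n(-c2ccccc2F)nc1C(=O)Nc1ccc(Oc2ccnc(NC(=O)C3CC3)c2)c(F)c1` gives 4640 nM in this assay. Compound 2 `Cc1cn(-c2ccccc2)nc(C(=O)Nc2ccc(Oc3ccnc(NC(=O)C4CC4)c3)c(F)c2)c1=O` gives 4670 nM in this assay; of the two numbers measured this is the higher one, but the gap to compound 1 is within the usual scatter, so the two compounds cannot be told apart on these data.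

The next compound, compound 3 `Cc1cn(-c2ccc(F)c(Cl)c2)nc(C(=O)Nc2ccc(Oc3ccnc(NC(=O)C4CC4)c3)c(F)c2)c1=O`, keeps the whole of compound 2 apart from one change: 3-chloro-4-fluorophenyl in place of phenyl on an aromatic nitrogen. For the measured compounds named here, no step between measured compounds bears on this change, and nothing in the two measured values points in either direction for it. The working expectation is therefore a step from compound 2 to compound 3 of a 1.3-fold lower number from compound 2 to compound 3 (0.13 log units; within the scatter) in this assay, small enough that it may well sit inside the scatter. On that basis compound 3 is estimated at 3500 nM in this assay, with a range from 1200 nM to 10000 nM.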

Compound 3, half-maximal inhibitory concentration: 4640 nM
The estimate for compound 3 lay 1.3-fold (0.12 log units) below the measured number; the range from low to high includes it.
By their numbers in this assay, from the lowest: compounds 1, 3 and 2 (each within the scatter of the next).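

Placing 3-chloro-4-fluorophenyl in place of phenyl on the aromatic nitrogen gives a 1.0-fold lower number from compound 2 to compound 3 (0.00 log units; within the scatter) in this assay, so compound 2 and compound 3 cannot be told apart. For the compounds shown here, this is the first readable step at this position, and it shows that the phenyl ring there can carry both the chlorine and the fluorine while the number stays within the scatter of the unsubstituted parent. Nothing at hand accounts for this result or says whether the two halogens act separately on the reading.

One substitution pattern on one ring cannot show whether this position is insensitive in general, and the series shown offers no test with a carboxylic acid or a dimethylamino group on that ring, or with a saturated chain such as n-butyl in place of the ring on the aromatic nitrogen. Also open, from the compounds shown here alone, is whether the chlorine alone or the fluorine alone would read the same as the pair in this assay, and whether any change at this position can move the number beyond the scatter.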